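Changing the group on the carbonyl of compound 1

The compounds below may be only part of what the source reports. "The series", "measured", "known", "first", "only" and "open" are said of these compounds alone.

Compound 1 `NNC(=O)CCc1ccncc1-c1ccc2ccccc2c1`: > 10000 nM (a limit)
Compound 2 `O=C(O)/C=C/c1ccncc1-c1ccc2ccccc2c1`: > 10000 nM (a limit)

In a functional assay on KB cells (Homo sapiens) for inhibition, read by sulforhodamine B assay, with a stated time of 72 h (a higher number here means a weaker inhibitor of growth, a lower number a stronger inhibitor of growth), compound 1 gives > 10000 nM, which is a limit of the assay and not a number. Compound 2 gives > 10000 nM, which is also a limit. So compound 1 has no exact position on the scale, and the whole picture so far rests on (the limit of > 10000 nM in this assay, at which 2 of the 2 values shown sit).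

Compound 3 `O=C(CCc1ccncc1-c1ccc2ccccc2c1)N1CCOCC1` keeps the core of compound 1 but carries morpholin-4-yl in place of aminoamino on a carbonyl carbon. The same change, cut one bond further out, reads aminocarbamoyl to (morpholin-4-yl)carbonyl.

Among the compounds with values here, the only measured step is a step that the two limits leave unreadable from compound 1 to compound 2. It changes a different part of the molecule and has no readable size, so it offers no size or direction to carry over. The working expectation in this assay is therefore no step beyond the scatter, and another limit is the likeliest result. The expected change is a step that the limit leaves unreadable from compound 1 to compound 3. For compound 3 the estimated value is 15000 nM, with an expected range of 6000 nM to 40000 nM.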

Compound 3, concentration for 50% growth inhibition: > 10000 nM
Compound 3: a limit, no number (the forecaster's own chance of this, stated with the estimate: 85%); the middle value lies beyond the limit too.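

In this assay compound 3 gives > 10000 nM, which is a limit of the assay and not a number. Within the data shown here, compound 1 also stands at a limit, so no step from compound 1 to compound 3 can be read. The compounds shown leave open how strongly any of them inhibits growth, and whether any change on the shared core would give a readable value: the limit of > 10000 nM in this assay, at which 3 of the 3 values shown sit.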